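Chain Length and Methyl Position in Indole Hydroxamates

A few compounds are considered here, and "the series" means these few. Any claim that something is new, unique, unknown or untested is made for them only; others in the source may bear on it.

Measured compounds:
Compound 1, `Cc1ccccc1Cc1cn(CCCCCC(=O)NO)c2ccc(-c3c(C)noc3C)cc12`, gives 15500 nM in a functional assay on THP-1 cells (Homo sapiens) for inhibition; a higher number here means a weaker inhibitor of growth, a lower number a stronger inhibitor of growth.
Compound 2, `Cc1ccccc1Cc1cn(CCCCCCC(=O)NO)c2ccc(-c3c(C)noc3C)cc12`, gives 15500 nM in this assay.
Compound 3, `Cc1cccc(Cc2cn(CCCCCC(=O)NO)c3ccc(-c4c(C)noc4C)cc23)c1`, gives 15500 nM in this assay.

Compound 2 differs from compound 1 by (hydroxycarbamoyl)methyl in place of hydroxycarbamoyl on a saturated chain carbon, five bonds along the chain from an aromatic nitrogen, and the step it made was no change at the digits printed from compound 1 to compound 2 (within the scatter). Compound 3 differs from compound 1 by 3-methylphenyl in place of 2-methylphenyl on a saturated chain carbon bound to an aromatic carbon, and that step was no change at the digits printed from compound 1 to compound 3 (within the scatter). Compound 4, `Cc1cccc(Cc2cn(CCCCCCC(=O)NO)c3ccc(-c4c(C)noc4C)cc23)c1`, has not been measured in this assay. It differs from compound 3 by (hydroxycarbamoyl)methyl in place of hydroxycarbamoyl on a saturated chain carbon, five bonds along the chain from an aromatic nitrogen, the same change that carries compound 1 to compound 2, made at the same place and occurring twice among these four compounds.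

Since that change gave no change at the digits printed from compound 1 to compound 2 (within the scatter) on the core of compound 1, and since compound 3 sits level with compound 1, the same change on the core of compound 3 is expected to give about no change at the digits printed from compound 3 to compound 4 (within the scatter). Compound 4 is therefore estimated at 15500 nM, expected to lie between 7000 nM and 35000 nM in this assay.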

Compound 4, concentration for 50% growth inhibition: 15500 nM
The estimate for compound 4 equals the measured number at the digits printed; the measured number falls inside the stated range.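

Carried to the core of compound 3, the longer chain gave no change at the digits printed from compound 3 to compound 4 (within the scatter) in this assay, which matches the step it made on the core of compound 1: the same change on two cores in this assay, no change at the digits printed (within the scatter) from compound 1 to compound 2 and no change at the digits printed (within the scatter) from compound 3 to compound 4, 1.0-fold (0.00 log units) apart, within the scatter of two such steps

Read on the longer chain, 3-methylphenyl in place of 2-methylphenyl gave no change at the digits printed from compound 2 to compound 4 (within the scatter), which also matches its earlier step: the same change on two cores in this assay, no change at the digits printed (within the scatter) from compound 1 to compound 3 and no change at the digits printed (within the scatter) from compound 2 to compound 4, 1.0-fold (0.00 log units) apart, within the scatter of two such steps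

Both changes therefore read the same on the two cores compared here, but every one of these steps is null, so this does not show how a change that actually moves the value would carry from one core to another, nor does it extend beyond these four compounds.

The compounds shown leave open whether a shorter or much longer chain, a carboxylic acid in place of the hydroxycarbamoyl group, or an unsubstituted phenyl in place of the methylphenyl would shift the value at all from that of compound 4, the 15500 nM measured here. If any of these did, it would remain to be seen whether that step held on both cores.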